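The source may hold more compounds than are shown below. What is called first, only, known or untested is meant among the compounds shown, and "the series" means these compounds.

Compounds measured in a functional assay on HCT-15 cells (Homo sapiens) for cytotoxicity, read by MTT assay, with a stated time of 2 days; on this read-out lower numbers stand for stronger inhibition and higher numbers for weaker inhibition:

compound 1 `COc1cccc(-c2nc3ccc(C)cc3c(=O)[nH]2)c1`
compound 2 `Cc1ccc2nc(-c3cccc(OC(F)(F)F)c3)[nH]c(=O)c2c1`
compound 3 `COc1cccc(-c2nc3cc(C)ccc3c(=O)[nH]2)c1`

In this assay compound 1 gives 32000 nM. Compound 3 gives 4850 nM, the lowest of the two numbers present. For compound 2 this assay reports only a limit, > 50000 nM, so the number itself is not known (the limit of > 50000 nM in this assay, at which 1 of the 3 values shown sits). Compound 1 and compound 3 have the same atoms joined differently; the difference between the two cores is not broken down here.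

The change from compound 1 to compound 2 is trifluoromethyl in place of methyl on an oxygen on an aromatic ring and gives an at least 1.5-fold higher number from compound 1 to compound 2 (0.19 log units; that floor lies within the scatter). The same change is now to be applied to compound 3, yielding compound 4 `Cc1ccc2c(=O)[nH]c(-c3cccc(OC(F)(F)F)c3)nc2c1`, not yet measured; the difference is trifluoromethyl in place of methyl on an oxygen on an aromatic ring.

Going by the values given here, only one earlier instance of this change exists, and its size is known only as a floor because compound 2 sits at the limit of > 50000 nM in this assay, at which 1 of the 3 values shown sits. A weaker number is expected for compound 4, and the step of a 3.1-fold higher number from compound 3 to compound 4 (0.49 log units; beyond the scatter) is estimated to be at least as large as the earlier one, with wide uncertainty. Compound 4 is estimated at 15000 nM, between 5000 nM and 50000 nM.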

Compound 4, half-maximal inhibitory concentration: > 50000 nM
Compound 4: a limit, no number; the forecaster's own chance of this, stated with the estimate: 25%; at least 3.3-fold (0.52 log units) between middle value and limit.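

In this assay, on the core of compound 3, methoxy to trifluoromethoxy gives an at least 10-fold higher number from compound 3 to compound 4 (1.01 log units; beyond the scatter), so on this core the change clearly weakens the read-out. Compound 4 gives > 50000 nM, which is a limit and not a number, and beside the core of compound 1 the change can therefore be compared only as two floors: the same change on two cores in this assay, an at least 1.5-fold higher number (0.19 log units; that floor lies within the scatter) from compound 1 to compound 2 and an at least 10-fold higher number (1.01 log units; beyond the scatter) from compound 3 to compound 4; the limit leaves it open whether they differ The change thus moves the number upward on both cores, but neither its true size on either core nor any ranking of the two trifluoromethoxy compounds can be read: the limit of > 50000 nM in this assay, at which 2 of the 4 values shown sit.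

Going by these compounds, whether another group on the oxygen, such as ethyl or a longer chain, would hold the number near that of compound 3 stays open. Also open, on these data alone, is how a hydroxyl, an amine or a carboxylic acid in place of methoxy would behave on either core.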